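Compound 2 to Compound 3: Changing One Aromatic Group

This account rests on a few compounds, and the source may have more. Where it says the series, first, only, none or still open, it means among the compounds named here.

In a functional assay on PC-3 cells (Homo sapiens) for antiproliferative activity, read by MTT assay, with a stated time of 48 h (a lower number here means a stronger inhibitor, a higher number a weaker inhibitor), compound 1 (`COc1ccc(CN(C(=O)CSc2nc3ccccc3s2)c2cc(OC)c(OC)c(OC)c2)cc1[N+](=O)[O-]`) gives 26500 nM and compound 2 (`COc1cc(N(Cc2ccc(F)cc2)C(=O)CSc2nc3ccccc3s2)cc(OC)c1OC`) gives 50800 nM. These two numbers are all that has been measured so far. They lie within the scatter of repeated measurements, so compound 2 cannot be ranked against compound 1. Compound 3 (`COc1ccc(CN(C(=O)CSc2nc3ccccc3s2)c2cc(OC)c(OC)c(OC)c2)cc1C(F)(F)F`) differs from compound 2 on a saturated chain carbon bound to an amide-type nitrogen: 4-methoxy-3-(trifluoromethyl)phenyl in place of 4-fluorophenyl on a saturated chain carbon bound to an amide-type nitrogen. Going by the values given here, the one measured step at that place, a 1.9-fold higher number from compound 1 to compound 2 (0.28 log units; within the scatter), put 4-fluorophenyl in place of 4-methoxy-3-nitrophenyl and stayed within the scatter. Among the compounds with values here, with only this step to go on, no shift beyond the scatter is expected in this assay, and the expected step is a 1.6-fold lower number from compound 2 to compound 3 (0.20 log units; within the scatter). Compound 3 is estimated at 32000 nM, with an expected range from 13000 nM to 75000 nM.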

Compound 3, half-maximal inhibitory concentration: > 80000 nM
Compound 3 ended at the assay's limit; the forecaster's own chance of this, stated with the estimate: 10%; at least 2.5-fold (0.39 log units) between middle value and limit.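

The value of compound 3 in this assay is a limit of the assay and not a number: the limit of > 80000 nM in this assay, at which 1 of the 3 values shown sits.

Changing 4-fluorophenyl to 4-methoxy-3-(trifluoromethyl)phenyl on a saturated chain carbon bound to an amide-type nitrogen gives an at least 1.5-fold higher number from compound 2 to compound 3 (0.19 log units; that floor lies within the scatter), so the true gap may be larger, but this floor alone does not rank the pair. Going by these compounds alone, the clearer finding concerns trifluoromethyl in place of nitro on an aromatic carbon, which gives an at least 3.0-fold higher number from compound 1 to compound 3 (0.47 log units; beyond the scatter); this is the first step to pass the scatter, showing that this one exchange can matter.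

On these data alone, how far compound 3 lies past its limit remains unknown, so the full size of both steps stays open. Also open, as far as these compounds go, is how an amine or a carboxylic acid on that aromatic carbon would compare with nitro and trifluoromethyl.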